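The source may hold more compounds than are shown below. What is called first, only, known or untested is meant among the compounds shown, and "the series" means these compounds.

Of the compounds shown here, three have been measured in a functional assay on DU-145 cells (Homo sapiens) for inhibition, read by trypan blue exclusion, with a stated time of 96 h; a higher number here means a weaker inhibitor of growth, a lower number a stronger inhibitor of growth. Compound 1 (`O=C(/C(=C\c1ccc(Cl)cc1Cl)S(=O)(=O)c1ccc(Br)cc1)c1ccc(Cl)cc1`) gives 50000 nM, compound 2 (`O=C(/C(=C\c1ccccc1F)S(=O)(=O)c1ccc(Br)cc1)c1ccc(Cl)cc1`) gives 25000 nM and compound 3 (`O=C(/C(=C\c1c(O)cc(O)cc1O)SCc1ccc(Cl)c(Cl)c1)c1ccc(Cl)cc1`) gives 25000 nM. Compound 3 therefore stands level with compound 2, and its gap to compound 1 lies within the scatter, so these numbers do not separate the three compounds.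

Compound 4 (`O=C(/C(=C\c1c(O)cc(O)cc1O)S(=O)(=O)c1ccc(Br)cc1)c1ccc(Cl)cc1`) keeps the rest of compound 3 but carries (4-bromophenyl)sulfonyl in place of (3,4-dichlorobenzyl)sulfanyl on a double-bonded chain carbon bound to a carbonyl carbon and a double-bonded chain carbon.

For the measured compounds named here, no measured step makes this exchange directly. Going by the values given here, the only step available, a 2.0-fold lower number from compound 1 to compound 2 (0.30 log units; within the scatter), puts 2-fluorophenyl in place of 2,4-dichlorophenyl elsewhere in the molecule, and it stays within the scatter. The entering group is already present in compound 2, which gives 25000 nM, the same number as compound 3 without that group. This is only a hint, since those two compounds also differ in a second place.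

No step beyond the scatter is therefore expected in this assay, in either direction. The expected step is a 1.3-fold lower number from compound 3 to compound 4 (0.10 log units; within the scatter). With so little direct evidence, the range is kept wide. The estimated value for compound 4 is 20000 nM, within a range of 6000 nM to 50000 nM.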

Compound 4, concentration for 50% growth inhibition: > 100000 nM
Compound 4 was reported as a limit (the forecaster's own chance of this, stated with the estimate: 10%); at least 5.0-fold (0.69 log units) between middle value and limit.
By their numbers in this assay, from the lowest: compounds 2, 3 and 1 (each within the scatter of the next). At a limit, above all of these: compound 4.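

Compound 4 is reported only as a limit, not as a number: the limit of > 100000 nM in this assay, at which 1 of the 4 values shown sits. For the compounds shown here, at the double-bonded chain carbon bound to a carbonyl carbon and a double-bonded chain carbon, the earlier compounds gave no direct reading, but with 2,4,6-trihydroxyphenyl held in place, this exchange of (3,4-dichlorobenzyl)sulfanyl for (4-bromophenyl)sulfonyl does change the result in this assay (an at least 4.0-fold higher number from compound 3 to compound 4 (0.60 log units; beyond the scatter)). With (4-bromophenyl)sulfonyl held in place, 2,4,6-trihydroxyphenyl also goes beyond the scatter against 2-fluorophenyl (an at least 4.0-fold higher number from compound 2 to compound 4 (0.60 log units; beyond the scatter)), whereas the floor against 2,4-dichlorophenyl does not (an at least 2.0-fold higher number from compound 1 to compound 4 (0.30 log units; that floor lies within the scatter)), so that last pair is not separated.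

The exchange alters the sulfur group and the ring group together, so the compounds shown cannot say which of the two parts matters, and (3,4-dichlorobenzyl)sulfonyl at the same place would pull them apart. As far as these compounds go, how far compound 4 really lies from the others also stays open, as does whether an amine or a carboxylic acid in place of the hydroxyl groups of 2,4,6-trihydroxyphenyl would shift the number in this assay at all.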